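The source may hold more compounds than are shown below. What is called first, only, known or untested is meant among the compounds shown, and "the series" means these compounds.

Measured in a functional assay on MDA-MB-231 cells (Homo sapiens), read by microscopy and transwell migration, with a stated time of 24 h; on this read-out lower numbers stand for stronger inhibition and higher numbers for weaker inhibition:

- Compound 1 `Cc1ccc(-c2cnc(NC(=O)c3ccccc3)s2)cc1`: 308 nM
- Compound 2 `COc1ccc(C(=O)Nc2nc(-c3cc(OC)c(OC)c(OC)c3)cs2)cc1`: > 25000 nM, a limit
- Compound 3 `COc1cc(-c2csc(NC(=O)c3ccc(Cl)cc3)n2)cc(OC)c1OC`: > 25000 nM, a limit

Compound 3 has no numerical value, only the limit > 25000 nM. Its place among the measured compounds is given by the limit of > 25000 nM in this assay, at which 2 of the 3 values shown sit.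

The step under consideration leads to compound 4 `COc1cc(-c2csc(NC(=O)c3cccc(OC)c3OC)n2)cc(OC)c1OC`, in which 2,3-dimethoxyphenyl stands in place of 4-chlorophenyl on a carbonyl carbon: 2,3-dimethoxyphenyl in place of 4-chlorophenyl on a carbonyl carbon.

Within the data shown here, one measured step bears on this change, since it also alters the group on that carbonyl carbon: a step that the two limits leave unreadable from compound 2 to compound 3. Its size cannot be read, so it sets no measured scale for the new step. Among the measured compounds shown here, compound 1 gives 308 nM, but it differs from the other two compounds in more than one place and offers no single-change step here.

In this assay, the expectation therefore rests on compound 2 and compound 3 sharing (the limit of > 25000 nM in this assay, at which 2 of the 3 values shown sit), and no clear gain is expected. The estimated change is a number no higher from compound 3 to compound 4 (the limit leaves the size open), with no shift expected beyond the scatter in either direction. For compound 4 the estimate is 25000 nM, with an expected range of 6000 nM to 60000 nM, and a report as a limit is considered likely.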

Compound 4, half-maximal inhibitory concentration: 15000 nM
Beside the measured number, compound 4's estimate is 1.7-fold (0.22 log units) above it, and the stated range covers the measured number.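

In this assay compound 4 gives 15000 nM, so 2,3-dimethoxyphenyl on this carbonyl carbon gives the first actual number for a compound with this core, and the position is shown to allow a readable value. The change reads as an at least 1.6-fold lower number from compound 3 to compound 4 (0.22 log units; that floor lies within the scatter), and the comparison with the 4-methoxyphenyl amide reads as an at least 1.6-fold lower number from compound 2 to compound 4 (0.22 log units; that floor lies within the scatter), so both steps establish only a floor, and neither shows a gain beyond the scatter. The step from compound 2 to compound 3 cannot be read, and compounds 2 and 3 remain limits, so the new number gives this position no ranking among its groups, only a first reading for one of them, set against the shared limit: the limit of > 25000 nM in this assay, at which 2 of the 4 values shown sit.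

The compounds shown leave open how far the true steps from compounds 2 and 3 extend, and whether both methoxy groups of compound 4 are needed for a value to appear. They also leave open how a morpholine or a carboxylic acid on the same carbonyl carbon would read, and compound 1, at 308 nM, differs from this series in more than one place and cannot settle either question.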